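The source may hold more compounds than are shown below. What is called first, only, known or untested is meant among the compounds shown, and "the series" means these compounds.

Measured compounds:

Compound 1, `O=C(/C(=C\c1ccc(Br)cc1)S(=O)(=O)c1ccc(Br)cc1)c1ccc(Br)cc1`, gives 10000 nM.
Compound 2, `O=C(/C(=C\c1ccc(F)cc1F)S(=O)(=O)c1ccc(Br)cc1)c1ccc(Br)cc1`, gives 7500 nM.
Compound 3, `O=C(/C(=C\c1ccc(Br)cc1)Sc1ccc(Br)cc1)c1ccc(Cl)cc1`, gives 1000 nM.

These three compounds were tested in a functional assay on DU-145 cells (Homo sapiens) for inhibition, read by trypan blue exclusion, with a stated time of 96 h; a lower number here means a stronger inhibitor of growth, a higher number a weaker inhibitor of growth. Compound 1 and compound 2 share one core and differ in a single place: 2,4-difluorophenyl in place of 4-bromophenyl on a double-bonded chain carbon bound to a double-bonded chain carbon. This change gave a 1.3-fold lower number from compound 1 to compound 2 (0.12 log units; within the scatter), so the two values cannot be told apart with confidence. Compound 3 rests on a different core; the difference between the two cores is not broken down here. In this assay compound 3 gives the lowest number of the three, and its step to compound 2 and its step to compound 1 both lie beyond the scatter.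

Compound 4, `O=C(/C(=C\c1ccc(F)cc1F)Sc1ccc(Br)cc1)c1ccc(Cl)cc1`, has not yet been measured. It stands to compound 3 exactly as compound 2 stands to compound 1: 2,4-difluorophenyl in place of 4-bromophenyl on a double-bonded chain carbon bound to a double-bonded chain carbon. The place is the same in both pairs, so this is the same change made on a second core. Among the compounds with values here, the only guide to its effect is the single earlier case, where it moved the number by a 1.3-fold lower number from compound 1 to compound 2 (0.12 log units; within the scatter), a shift that stays within the scatter. On that basis compound 4 is expected to remain close to compound 3, with an estimated step of a 1.3-fold lower number from compound 3 to compound 4 (0.10 log units; within the scatter). Because compound 3 gives 1000 nM, the estimate for compound 4 is 800 nM, expected to fall between 400 nM and 2000 nM.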

Compound 4, concentration for 50% growth inhibition: 1000 nM
Estimate against measurement, compound 4: 1.3-fold (0.10 log units) below; measured number inside the range.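

In this assay, putting 2,4-difluorophenyl in place of 4-bromophenyl on a double-bonded chain carbon bound to a double-bonded chain carbon gives no change at the digits printed from compound 3 to compound 4 (within the scatter). Set beside the earlier case, the change looks the same on the second core as on the first, as far as this assay can separate such steps: the same change on two cores in this assay, a 1.3-fold lower number (0.12 log units; within the scatter) from compound 1 to compound 2 and no change at the digits printed (within the scatter) from compound 3 to compound 4, 1.3-fold (0.12 log units) apart, within the scatter of two such steps. This agreement is a modest result, since neither step stands out from the scatter: it shows that this one change left the number unresolved on both cores, but not that the change is without any effect, and not that a change with a large step on one core would carry over to another with the same size.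

The compounds shown leave open whether a group of a different kind at this same place, such as a phenyl ring carrying an amine or a carboxylic acid, would give a step beyond the scatter, and whether that step would then be the same on both cores. Within the data shown here, they also leave open whether the agreement seen here would hold on a third core, as only two cores are compared.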